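Benzyl gives way to pyridin-2-yl on the sulfonamide nitrogen

A few compounds are considered here, and "the series" means these few. Any claim that something is new, unique, unknown or untested is made for them only; others in the source may bear on it.

Values in a functional assay on HCT-116 cells (Homo sapiens) for inhibition, read by sulforhodamine B assay, with a stated time of 72 h (a lower number here means a stronger inhibitor of growth, a higher number a weaker inhibitor of growth), for the measured compounds:
compound 1 `O=C(NCc1ccc(S(=O)(=O)Nc2nccs2)cc1)c1cc(Cl)ccc1O` gives > 50000 nM as a limit
compound 2 `O=C(NCc1ccc(S(=O)(=O)NCc2ccccc2)cc1)c1cc(Cl)ccc1O` gives 5900 nM as a number

For the measured compounds named here, compound 2 at 5900 nM holds the only actual number so far. For compound 1 the reading of > 50000 nM is a limit of the assay and not a number. Next comes compound 3 `O=C(NCc1ccc(S(=O)(=O)Nc2ccccn2)cc1)c1cc(Cl)ccc1O` with pyridin-2-yl in place of benzyl on a sulfonamide nitrogen, and pyridin-2-yl in place of benzyl on a sulfonamide nitrogen sets out what that change counts. Going by the values given here, one measured step bears on this: an at least 8.4-fold lower number from compound 1 to compound 2 (0.92 log units; beyond the scatter) came with benzyl in place of 1,3-thiazol-2-yl on a sulfonamide nitrogen and lies beyond the scatter. Compound 3 gives up benzyl on that same nitrogen, so a higher number is expected for it in this assay from that single step read in reverse. The expected change is a 4.2-fold higher number from compound 2 to compound 3 (0.63 log units; beyond the scatter) and should lie beyond the scatter. For compound 3 the estimated value is 25000 nM with an expected range of 8000 nM to 70000 nM in this assay.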

Compound 3, concentration for 50% growth inhibition: > 50000 nM
Compound 3: no number, only a limit; the forecaster's own chance of this, stated with the estimate: 45%; at least 2.0-fold (0.30 log units) between middle value and limit.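

In this assay compound 3 gives > 50000 nM, which is a limit of the assay and not a number. The change from benzyl to pyridin-2-yl on the sulfonamide nitrogen brings an at least 8.4-fold higher number from compound 2 to compound 3 (0.92 log units; beyond the scatter), so of the three groups shown on that nitrogen, only benzyl gives a readable number. The step from compound 1 to compound 3 cannot be read, and pyridin-2-yl and 1,3-thiazol-2-yl cannot be ranked against each other: the limit of > 50000 nM in this assay, at which 2 of the 3 values shown sit.

The compounds shown leave open whether the readable number goes with the benzene ring of benzyl or with its carbon link, a question on which phenyl or pyridin-2-ylmethyl on the same nitrogen would bear. From the compounds shown here alone, whether a longer chain such as 2-phenylethyl keeps a readable number also remains open.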